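Benzoyl to (3,4-dichlorophenyl)carbamoyl: a large gain expected

This account rests on a few compounds, and the source may have more. Where it says the series, first, only, none or still open, it means among the compounds named here.

Compound 1 `COc1cc(-c2nn(-c3cccc(NC(=O)c4cccc(C(F)(F)F)c4)c3)cc2-c2ccncc2)ccc1Cl`: in a functional assay on UACC-257 cells (Homo sapiens) for inhibition, read by sulforhodamine B assay, with a stated time of 48 h (on this read-out lower numbers stand for stronger inhibition of growth and higher numbers for weaker inhibition of growth), compound 1 gives > 50000 nM, which is a limit of the assay and not a number.
Compound 2 `COc1cc(-c2nn(-c3cccc(NC(=O)Nc4ccc(Cl)c(C(F)(F)F)c4)c3)cc2-c2ccncc2)ccc1Cl`: in this assay compound 2 gives 6030 nM.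
Compound 3 `COc1cc(-c2nn(-c3cccc(NC(=O)c4ccccc4)c3)cc2-c2ccncc2)ccc1Cl`: in this assay compound 3 gives > 100000 nM, again a limit and not a number.

Compound 3 therefore stands only as a limit, with no number of its own, and only compound 2 carries a real value. Compound 4 `COc1cc(-c2nn(-c3cccc(NC(=O)Nc4ccc(Cl)c(Cl)c4)c3)cc2-c2ccncc2)ccc1Cl` differs from compound 3 by (3,4-dichlorophenyl)amino in place of phenyl on a carbonyl carbon. The step that bears on this is an at least 16-fold higher number from compound 2 to compound 3 (1.21 log units; beyond the scatter), a large step; the move from compound 3 to compound 4 runs the same change backwards. The step of an at least 8.2-fold lower number from compound 1 to compound 2 (0.91 log units; beyond the scatter) points the same way. A large lowering is therefore expected, an at least 12-fold lower number from compound 3 to compound 4 (1.09 log units; beyond the scatter). Compound 4 is estimated at 8000 nM, with a range from 2500 nM to 30000 nM.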

Compound 4, concentration for total growth inhibition: 3110 nM
Beside the measured number, compound 4's estimate is 2.6-fold (0.41 log units) above it, within the range that was stated.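

Compound 4 gives a second real number with an aryl amino group on the carbonyl carbon, as (3,4-dichlorophenyl)amino in this assay yields an at least 32-fold lower number from compound 3 to compound 4 (1.50 log units; beyond the scatter) and an at least 16-fold lower number from compound 1 to compound 4 (1.20 log units; beyond the scatter). Compound 1 and compound 3 each stand only as a limit of the assay, so these two steps have a floor and no exact size. Chloro and trifluoromethyl cannot be told apart here, with a 1.9-fold lower number from compound 2 to compound 4 (0.29 log units; within the scatter), so the aromatic ring takes either group without a readable difference.

Still open, as far as these compounds go, is how a methylene in place of the amino nitrogen would read in this assay. The same holds for an amine or a carboxylic acid in place of the chloro groups.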